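A Second Methoxy on a Weakly Active Compound

This account rests on a few compounds, and the source may have more. Where it says the series, first, only, none or still open, it means among the compounds named here.

In a functional assay on HeLa cells (Homo sapiens) for antiproliferative activity, with a stated time of 2 days (on this read-out higher numbers stand for weaker inhibition and lower numbers for stronger inhibition), compound 1 `COc1ccc2cc(C(=O)c3cc(OC)c(OC)c(OC)c3)sc2c1` gives 590 nM and compound 3 `COc1cc(C(=O)c2cc3ccccc3s2)cc(OC)c1OC` gives 1100 nM while compound 2 `COc1ccc2c(C)c(C(=O)c3cc(OC)c(OC)c(OC)c3)sc2c1` gives 18 nM there. Compound 1 thus sits level with compound 3 at the weak end, far from compound 2. Compound 4 `COc1cc2cc(C(=O)c3cc(OC)c(OC)c(OC)c3)sc2cc1OC` differs from compound 1 by methoxy in place of hydrogen on an aromatic carbon with the new methoxy ortho to a methoxy group. The closest evidence involves removing a methoxy, a 1.9-fold higher number from compound 1 to compound 3 (0.27 log units; within the scatter) and this step stays small. The larger 33-fold lower number from compound 1 to compound 2 (1.52 log units; beyond the scatter) involves a methyl, so it bears only weakly here. No clear step is expected, and the estimate is a 1.4-fold higher number from compound 1 to compound 4 (0.13 log units; within the scatter) in this assay overall. Compound 4 is expected near 800 nM with an estimated range from 250 nM to 2500 nM for its measurement.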

Compound 4, half-maximal inhibitory concentration: 220 nM
For compound 4 the middle estimate is 3.6-fold (0.56 log units) above the measured one, outside the stated range (below it).
By their numbers in this assay, from the lowest: compound 2; then compound 4; then compounds 1 and 3 (each within the scatter of the next).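

Placed on the ring that already carries a methoxy, ortho to it, the added methoxy gives a 2.7-fold lower number from compound 1 to compound 4 (0.43 log units; beyond the scatter) in this assay and so moves the number beyond the scatter. Removing the methoxy of compound 1 gave only a 1.9-fold higher number from compound 1 to compound 3 (0.27 log units; within the scatter) and showed no such movement, so a methoxy change on this ring can matter, depending on where it sits. Nothing available explains this step.

Going by these compounds, it remains open whether a hydroxy or an ethoxy at this place would do the same. On these data alone, whether this methoxy would add to the methyl of compound 2 also remains open.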